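A few compounds are considered here, and "the series" means these few. Any claim that something is new, unique, unknown or untested is made for them only; others in the source may bear on it.

Measured in a functional assay on K562 cells (Homo sapiens) for inhibition, read by fluorescence, with a stated time of 72 h; a higher number here means a weaker inhibitor of growth, a lower number a stronger inhibitor of growth:
- compound 1 `COc1ccc(Nc2nc(N[C@H]3CC[C@H](N)CC3)nc3c2ncn3CCC(C)C)c(OC)c1`: 5500 nM
- compound 2 `CC(C)CCn1cnc2c(Nc3cccc(Cl)c3)nc(N[C@H]3CC[C@H](N)CC3)nc21`: 1500 nM

Of these two, compound 2 stands lowest at 1500 nM. Compound 3 `CC(C)CCn1cnc2c(Nc3ccccc3)nc(N[C@H]3CC[C@H](N)CC3)nc21` differs from it in one place: hydrogen in place of chloro on an aromatic carbon. Going by the values given here, the only measured step bearing on this group is a 3.7-fold lower number from compound 1 to compound 2 (0.56 log units; beyond the scatter), which is modest and does not isolate the chloro. A smaller step toward a higher number is therefore expected in this assay. The estimate means a 1.7-fold higher number from compound 2 to compound 3 (0.22 log units; within the scatter). Compound 3 is expected at 2500 nM, with an estimated range of 1000 nM to 6500 nM.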

Compound 3, concentration for 50% growth inhibition: 3500 nM
The estimate for compound 3 lay 1.4-fold (0.15 log units) below the measured number, and the stated range covers the measured number.
By their numbers in this assay, from the lowest: compound 2; then compounds 3 and 1 (each within the scatter of the next).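

Going by these compounds alone, the chloro on the aromatic carbon is isolated here for the first time: in this assay, its removal gives a 2.3-fold higher number from compound 2 to compound 3 (0.37 log units; beyond the scatter), a step of its own. The plain phenyl, with a 1.6-fold lower number from compound 1 to compound 3 (0.20 log units; within the scatter), stays within the scatter of the 2,4-dimethoxyphenyl, so on these numbers only the 3-chlorophenyl compound stands apart from the other two. No evidence at hand bears on the reason for this.

On these data alone, whether a bromo, a methyl or a trifluoromethyl on that aromatic carbon would give a step like the chloro's remains open. So does whether the chloro's step would hold with a shorter chain in place of the one these compounds share.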